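Methyl in Place of Bromo: A Cytotoxicity Expectation

The compounds below may be only part of what the source reports. "The series", "measured", "known", "first", "only" and "open" are said of these compounds alone.

The study tested three compounds in an ADME assay on HepG2 2.2.15 cells (Homo sapiens) for cytotoxicity, read by MTT assay, with stated times of 3 days and 7 days; on this read-out higher numbers stand for lower toxicity in this test and lower numbers for higher toxicity in this test. Compound 1 `COc1ccc(-c2cc(C(=O)OCc3ccccc3)c3ccccc3n2)cc1` was the first; in this assay compound 1 gives > 20000 nM, which is a limit of the assay rather than a number. Compound 2 `O=C(c1cc(-c2cccc(Br)c2)nc2ccccc12)N1CCC(Cc2ccccc2)CC1` carries a 3-bromophenyl on the shared core; in this assay compound 2 gives > 20000 nM, again a limit. Compound 3 `Cc1ccc([C@H](C)NC(=O)c2cc(-c3cccc(C)c3)nc3ccccc23)cc1` carries a 3-methylphenyl instead; in this assay compound 3 gives > 20000 nM, also a limit. Going by the values given here, compound 2 therefore stands at the same place as every other value shown, since the limit of > 20000 nM in this assay, at which 3 of the 3 values shown sit, and no compound separates itself from that level.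

Compound 4 `Cc1cccc(-c2cc(C(=O)N3CCC(Cc4ccccc4)CC3)c3ccccc3n2)c1` differs from compound 2 by methyl in place of bromo on an aromatic carbon. Among the compounds with values here, no pair of measured compounds differs in a single place, so no measured step sizes this change. Because the limit of > 20000 nM in this assay, at which 3 of the 3 values shown sit, holds for compound 2 and both of its companions, the step from compound 2 to compound 4 is expected to be a step that the limit leaves unreadable from compound 2 to compound 4, meaning no movement beyond the scatter in either direction. Compound 4 is accordingly estimated to give about 30000 nM, within a range from 15000 nM to 60000 nM, and is expected most likely to be reported again only as a limit.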

Compound 4, half-maximal cytotoxic concentration: > 20000 nM
Compound 4: no number, only a limit; the forecaster's own chance of this, stated with the estimate: 85%; the middle value is on the limit's open side.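

In this assay compound 2 and compound 4 both stand only as limits and not as numbers, so no step between them can be read, and the reason is this: the limit of > 20000 nM in this assay, at which 4 of the 4 values shown sit. The compounds shown leave open at what concentration any of them would become toxic in this assay and whether methyl in place of bromo alters that concentration.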